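From methyl to propyl in an ecdysone agonist series

The compounds below may be only part of what the source reports. "The series", "measured", "known", "first", "only" and "open" are said of these compounds alone.

Of the compounds shown here, three have been measured in an assay on cells for agonist activity at ecdysone receptor (Bombyx mori), read by a luciferase reporter, with a stated time of 24 h; on this read-out lower numbers stand for an effect already at smaller amounts and higher numbers for an effect only at larger amounts of compound. Compound 1 `CC(C)(C)N(NC(=O)c1ccc(F)cc1)C(=O)c1ccccc1Cl` gives 389 nM, compound 2 `CC(C)(C)N(NC(=O)c1ccc(Cl)cc1)C(=O)c1ccccc1Cl` gives 115 nM, and compound 3 `Cc1ccc(C(=O)NN(C(=O)c2ccccc2Cl)C(C)(C)C)cc1` gives 18.6 nM, the lowest of the three. The measured steps show a 3.4-fold lower number from compound 1 to compound 2 (0.53 log units; beyond the scatter), a 21-fold lower number from compound 1 to compound 3 (1.32 log units; beyond the scatter) and a 6.2-fold lower number from compound 2 to compound 3 (0.79 log units; beyond the scatter). Compound 4 `CCCc1ccc(C(=O)NN(C(=O)c2ccccc2Cl)C(C)(C)C)cc1` differs from compound 3 by ethyl in place of hydrogen on a saturated chain carbon bound to an aromatic carbon. Among the compounds with values here, no measured step lengthens a chain on this aromatic carbon, so the earlier steps bear on it only loosely: each lowered the number when fluoro gave way to chloro or methyl. The reviewer therefore expects a small further drop in this assay for compound 4, a 1.9-fold lower number from compound 3 to compound 4 (0.27 log units; within the scatter), near the edge of the scatter. The estimate for compound 4 is 10 nM, ranging from 3 nM to 40 nM.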

Compound 4, half-maximal effective concentration: 9.12 nM
The estimate for compound 4 lay 1.1-fold (0.04 log units) above the measured number; measured number inside the range.
By their numbers in this assay, from the lowest: compound 4; then compound 3; then compound 2; then compound 1.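

In this assay, within the data shown here, the change from methyl to propyl gave a 2.0-fold lower number from compound 3 to compound 4 (0.31 log units; beyond the scatter) and so extended the chain without losing the low number of compound 3, a step that the earlier compounds, which differ only in the group on the aromatic carbon, could not show. Propyl also stands well clear of the halogens, with a 13-fold lower number from compound 2 to compound 4 (1.10 log units; beyond the scatter) and a 43-fold lower number from compound 1 to compound 4 (1.63 log units; beyond the scatter) in the same read-out. No evidence bearing on the reason for these steps is available. From the compounds shown here alone, whether a longer chain such as butyl or hexyl would lower the number further remains open, as does the effect of a branched isopropyl group or an amine at the end of the chain.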